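The source may report more compounds than this note shows. Statements on the series, on what has been measured and on what is new or still open speak of the compounds shown alone.

Measured compounds:
- compound 1, `Cc1cc(O)c(C2=NN(c3ccc(S(N)(=O)=O)cc3)C(c3ccccc3O)C2)cc1Cl`, 18200 nM
- compound 2, `Cc1cc(O)c(C2=NN(c3ccc(S(N)(=O)=O)cc3)C(c3ccccc3Cl)C2)cc1Cl`, 12300 nM
- compound 3, `COc1ccc(C2CC(c3cc(Cl)c(C)cc3O)=NN2c2ccc(S(N)(=O)=O)cc2)cc1OC`, 15200 nM

All three values come from a functional assay on SK-MEL-5 cells (Homo sapiens) for antiproliferative activity, with a stated time of 48 h; a lower number here means a stronger inhibitor of growth, a higher number a weaker inhibitor of growth. Compound 3 sits second highest of the three numbers, with compound 1 nearest (a 1.2-fold lower number from compound 1 to compound 3 (0.08 log units; within the scatter)) and compound 2 furthest (a 1.2-fold higher number from compound 2 to compound 3 (0.09 log units; within the scatter)); every gap between the three is within the scatter, so none can be ranked against another.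

Compound 4, `COc1ccc(C2CC(c3cc(Cl)c(C)cc3O)=NN2c2ccc(S(N)(=O)=O)cc2)c(OC)c1OC`, has not yet been measured. It differs from compound 3 in one place: methoxy in place of hydrogen on an aromatic carbon.

For the measured compounds named here, two measured steps bear on the question, both exchanging the pendant aryl group on the saturated ring carbon: a 1.2-fold lower number from compound 1 to compound 3 (0.08 log units; within the scatter) and a 1.2-fold higher number from compound 2 to compound 3 (0.09 log units; within the scatter). Both stay within the scatter, as does the ring substitution step a 1.5-fold lower number from compound 1 to compound 2 (0.17 log units; within the scatter). Going by the values given here, nothing among the measured compounds suggests that a further methoxy on that aryl ring would move the number beyond the scatter in either direction. The expected step is therefore small, a 1.0-fold lower number from compound 3 to compound 4 (0.01 log units; within the scatter). Compound 4 is estimated at 15000 nM in this assay, with a range from 7000 nM to 35000 nM.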

Compound 4, concentration for total growth inhibition: 4180 nM
The estimate for compound 4 lay 3.6-fold (0.55 log units) above the measured number, and the stated range ends above it.
By their numbers in this assay, from the lowest: compound 4; then compounds 2, 3 and 1 (each within the scatter of the next).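

In this assay, for the compounds shown here, this position, on an aromatic carbon ortho to a large group and ortho to a methoxy group, gives the first change that moves the number beyond the scatter, a 3.6-fold lower number from compound 3 to compound 4 (0.56 log units; beyond the scatter), whereas the aryl exchanges among compound 1, compound 2 and compound 3 did not. The 2,3,4-trimethoxyphenyl group also separates from the two other aryl groups carrying a single substituent, with a 2.9-fold lower number from compound 2 to compound 4 (0.47 log units; beyond the scatter) and a 4.4-fold lower number from compound 1 to compound 4 (0.64 log units; beyond the scatter), which leaves compound 4 with the lowest number of the four. No measurement here accounts for this step.

Only methoxy is shown at this position, so an ethoxy, a fluoro or an amine there remains an open case. Also open, on these data alone, is whether methoxy at this position would give a similar step without the other methoxy groups on the ring.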